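From Compound 3 to Its Chloro Analogue

The compounds below may be only part of what the source reports. "The series", "measured", "known", "first", "only" and "open" are said of these compounds alone.

In a functional assay on Hs-578T cells (Homo sapiens) for inhibition, read by sulforhodamine B assay, with a stated time of 48 h (on this read-out lower numbers stand for stronger inhibition of growth and higher numbers for weaker inhibition of growth), compound 1 `N#Cc1c(-c2nnc(O)c3nn(-c4ccccc4)cc23)nn(-c2ccccc2)c1-c1ccccc1` gives 46800 nM. Compound 2 `N#Cc1c(-c2nnc(O)c3nn(-c4ccc(Cl)cc4)cc23)nn(-c2ccccc2)c1-c1ccccc1` reads > 100000 nM, which is a limit of the assay and not a number. Compound 3 `N#Cc1c(-c2nnc(-c3nn(-c4ccccc4)c(-c4ccccc4)c3C#N)c3nn(-c4ccccc4)cc23)nn(-c2ccccc2)c1-c1ccccc1` gives 94400 nM, within the scatter of compound 1. Compound 4 `N#Cc1c(-c2nnc(-c3nn(-c4ccccc4)c(-c4ccccc4)c3C#N)c3nn(-c4ccc(Cl)cc4)cc23)nn(-c2ccccc2)c1-c1ccccc1` differs from compound 3 by chloro in place of hydrogen on an aromatic carbon, a change of phenyl to 4-chlorophenyl. The same change has one measured precedent, an at least 2.1-fold higher number from compound 1 to compound 2 (0.32 log units; beyond the scatter), and that step, beyond the scatter, ends at the limit of > 100000 nM in this assay, at which 1 of the 3 values shown sits. On that precedent, a step of similar size towards weaker inhibition of growth is expected, estimated as a 2.1-fold higher number from compound 3 to compound 4 (0.33 log units; beyond the scatter). Compound 4 is estimated at 200000 nM, with an expected range from 80000 nM to 500000 nM, and it may well be reported only as a limit.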

Compound 4, concentration for 50% growth inhibition: 9720 nM
For compound 4 the middle estimate is 21-fold (1.31 log units) above the measured one; the whole stated range lies above it.
By their numbers in this assay, from the lowest: compound 4; then compounds 1 and 3 (each within the scatter of the next). At a limit, above all of these: compound 2.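

The step to 4-chlorophenyl at this position gives a 9.7-fold lower number from compound 3 to compound 4 (0.99 log units; beyond the scatter) in this assay, so on the core of compound 3 chloro goes with stronger inhibition of growth. The earlier pair showed only the opposite direction, so the effect of this change is not fixed and differs with the core that carries it: the same change on two cores in this assay, an at least 2.1-fold higher number (0.32 log units; beyond the scatter) from compound 1 to compound 2 and a 9.7-fold lower number (0.99 log units; beyond the scatter) from compound 3 to compound 4, at least 20-fold (1.31 log units) apart, beyond the scatter of two such steps

The compounds shown leave open whether fluoro, methoxy or an amine in place of chloro would follow compound 4 or compound 2. They also leave open which part of the larger core of compound 3 goes with the reversal.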